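The source may report more compounds than this note shows. Statements on the series, on what has been measured and on what is new or still open speak of the compounds shown alone.

Measured compounds:
compound 1 `Cc1csc(-c2nc(N)c3cc(Cc4ccccc4)sc3n2)n1`, 1490 nM
compound 2 `Cc1csc(-c2nc(N)c3cc(Cc4ccccc4F)sc3n2)n1`, 28.6 nM
compound 3 `Cc1csc(-c2nc(N)c3cc(C(C)c4ccccc4)sc3n2)n1`, 1420 nM

These three share one core and differ only in the group hanging from it. In a functional assay on CHO-K1 cells for antagonist activity at adenosine receptor A1 (Homo sapiens), read by a beta-galactosidase reporter and cAMP accumulation, with stated times of 15 min and 6 h (on this read-out higher numbers stand for weaker inhibition and lower numbers for stronger inhibition), compound 1 gives the highest of the three numbers; its nearest neighbour is compound 3, at a 1.0-fold lower number from compound 1 to compound 3 (0.02 log units; within the scatter), and its furthest is compound 2, at a 52-fold lower number from compound 1 to compound 2 (1.72 log units; beyond the scatter). The change to the unmeasured compound 4 `Nc1nc(-c2ccncc2)nc2sc(Cc3ccccc3)cc12` is of a different kind: pyridin-4-yl in place of 4-methyl-1,3-thiazol-2-yl on an aromatic carbon. For the measured compounds named here, every measured step touches the benzyl side of the molecule, while the 4-methyl-1,3-thiazol-2-yl group stays the same throughout; no step therefore speaks to swapping it for pyridin-4-yl. The large step of a 52-fold lower number from compound 1 to compound 2 (1.72 log units; beyond the scatter) and the flat step a 1.0-fold lower number from compound 1 to compound 3 (0.02 log units; within the scatter) show that small changes can have very different outcomes, so the uncertainty is wide. With nothing pointing either way, compound 4 is expected to stay near compound 1, at a 1.0-fold higher number from compound 1 to compound 4 (0.00 log units; within the scatter). The estimate for compound 4 in this assay is 1500 nM, in a range from 250 nM to 9000 nM.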

Compound 4, inhibition constant: 812 nM
For compound 4 the middle estimate is 1.8-fold (0.27 log units) above the measured one; the range from low to high includes it.
By their numbers in this assay, from the lowest: compound 2; then compounds 4, 3 and 1 (each within the scatter of the next).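

For the compounds shown here, this is the first change to the group on the aromatic carbon between two ring nitrogen atoms. In this assay, pyridin-4-yl in place of 4-methyl-1,3-thiazol-2-yl gives a 1.8-fold lower number from compound 1 to compound 4 (0.26 log units; within the scatter), so with the benzyl group unchanged, this swap of one aromatic ring for another leaves the number within the usual spread of repeat measurements, a contrast with the fluoro step on the benzyl side, a 52-fold lower number from compound 1 to compound 2 (1.72 log units; beyond the scatter). No measurement here bears on why the two rings read alike.

On these data alone, it remains open whether the 2-fluorobenzyl group of compound 2 would give a similar step when paired with pyridin-4-yl. As far as these compounds go, it also remains open how this position would respond to something other than these two aromatic rings, such as a plain phenyl ring, an amine or a longer chain.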